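Swapping a Pyrimidine for a Thiazole on the Sulfur Linker

The compounds below may be only part of what the source reports. "The series", "measured", "known", "first", "only" and "open" are said of these compounds alone.

Compound 1 `C=C1CC[C@@H]2[C@](C)(CO)[C@H](O)CC[C@@]2(C)[C@@H]1CC(Sc1ccc(OC)cc1)C1=CCOC1=O` gives 15000 nM in a functional assay on PC-3 cells (Homo sapiens) for inhibition, read by MTT assay, with a stated time of 48 h; on this read-out lower numbers stand for stronger inhibition and higher numbers for weaker inhibition.
Compound 2 `C=C1CC[C@@H]2[C@](C)(CO)[C@H](O)CC[C@@]2(C)[C@@H]1CC(Sc1ncccn1)C1=CCOC1=O` gives 7000 nM in this assay.

Of the compounds shown here, two have been measured in this assay, and they share a common core that carries a sulfur-linked aromatic group. Going by the values given here, the only step so far, a 2.1-fold lower number from compound 1 to compound 2 (0.33 log units; beyond the scatter), changed that aromatic group. Among the compounds with values here, on these two numbers compound 2 stands lowest, with compound 1 as its only neighbour.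

Compound 3 `C=C1CC[C@@H]2[C@](C)(CO)[C@H](O)CC[C@@]2(C)[C@@H]1CC(Sc1nccs1)C1=CCOC1=O` has not yet been measured in this assay. It differs from compound 2 in one place: 1,3-thiazol-2-yl in place of pyrimidin-2-yl on a sulfur.

Within the data shown here, no measured step bears directly on this exchange, since the one step on hand, a 2.1-fold lower number from compound 1 to compound 2 (0.33 log units; beyond the scatter), compares a methoxyphenyl with a pyrimidine rather than a pyrimidine with a thiazole. That step was modest, so a change of similar or smaller size seems plausible here. Without a direct precedent, the expectation is a step of a 1.2-fold lower number from compound 2 to compound 3 (0.07 log units; within the scatter) in this assay, which stays near the scatter in either direction. Compound 3 is therefore estimated at 6000 nM, with a likely range from 2500 nM to 15000 nM.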

Compound 3, half-maximal inhibitory concentration: 14000 nM
Estimate against measurement, compound 3: 2.3-fold (0.37 log units) below, within the range that was stated.
By their numbers in this assay, from the lowest: compounds 2, 3 and 1 (each within the scatter of the next, the first and the last beyond it).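

In this assay, 1,3-thiazol-2-yl on the sulfur gives a 2.0-fold higher number from compound 2 to compound 3 (0.30 log units; within the scatter) when it takes the place of pyrimidin-2-yl, and a 1.1-fold lower number from compound 1 to compound 3 (0.03 log units; within the scatter) when it takes the place of 4-methoxyphenyl, so compound 3 cannot be told apart from either neighbour. Going by these compounds alone, this position therefore accepts a five-membered aromatic ring as well as the six-membered rings without a change that this read-out can resolve, and the only pair printed as beyond the scatter remains the one with a 2.1-fold lower number from compound 1 to compound 2 (0.33 log units; beyond the scatter), itself a modest step. Nothing measured here explains why these aromatic groups read as they do, and compound 3 does not settle whether the gap between compound 1 and compound 2 reflects any real preference at this sulfur.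

On these data alone, all three groups on the sulfur are aromatic rings, so it remains open how a plain ethyl chain, a chain ending in an amine or one ending in a carboxylic acid would read here. As far as these compounds go, it is also open whether the sulfur itself matters, since an oxygen or a nitrogen in its place would be a separate question for the same aromatic groups.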